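The compounds below may be only part of what the source reports. "The series", "measured", "known", "first", "only" and "open" are said of these compounds alone.

Within the data shown here, compound 2, with the structure `Cc1c(Cc2ccccc2S(=O)(=O)c2ccccc2F)c2c(n1CC(=O)O)CCNC2=O`, is the compound with the lowest number of the two measured so far. In a functional assay on CHO.K1 cells for antagonist activity at prostaglandin D2 receptor 2 (Homo sapiens), read by GTPgammaS binding, with a stated time of 1 h (on this read-out higher numbers stand for weaker inhibition and lower numbers for stronger inhibition), compound 2 gives 3.6 nM. Compound 1, with the structure `Cc1c(Cc2ccc(C(=O)O)cc2S(=O)(=O)c2ccccc2)c2c(n1CC(=O)O)CCNC2=O`, shares the same core but differs from compound 2 at more than one place, so no single step can be read between them; in this assay compound 1 gives 19 nM, a higher number than compound 2, and the gap lies beyond the usual scatter. Compound 3, with the structure `Cc1c(Cc2ccccc2S(=O)(=O)c2cccc(Cl)c2)c2c(n1CC(=O)O)CCNC2=O`, has not yet been measured. Among the measured compounds shown here, its only change from compound 2 is 3-chlorophenyl in place of 2-fluorophenyl on a sulfonyl sulfur. For the measured compounds named here, no measured pair shows this particular change, so its effect cannot be read from the numbers at hand. The expected step is a 1.4-fold higher number from compound 2 to compound 3 (0.14 log units; within the scatter), at most a little beyond the scatter in either direction. Compound 3 is therefore expected to give 5 nM in this assay, within a range from 1.5 nM to 15 nM.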

Compound 3, half-maximal inhibitory concentration: 4 nM
Beside the measured number, compound 3's estimate is 1.3-fold (0.10 log units) above it; low and high end bracket the measured number.
By their numbers in this assay, from the lowest: compounds 2 and 3 (each within the scatter of the next); then compound 1.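

In this assay, among these compounds, the first comparison that differs in one place gives a 1.1-fold higher number from compound 2 to compound 3 (0.05 log units; within the scatter). On a sulfonyl sulfur, then, 3-chlorophenyl and 2-fluorophenyl cannot be told apart on this read-out, so this position keeps its low nanomolar numbers with either group. Because the halogen and its place on the ring change together, this single step cannot separate the two, and no measurement at hand offers an explanation of why the two groups read alike.

Still open, going by these compounds, is how the position responds to a phenyl ring carrying a nitrile or an amine instead of a halogen. Among the compounds shown here, compound 1 differs from the others in more than one place, so no step involving it can be read.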